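A Methoxyphenyl Variant of an Indazole Sulfone Antagonist

A few compounds are considered here, and "the series" means these few. Any claim that something is new, unique, unknown or untested is made for them only; others in the source may bear on it.

Of the compounds shown here, two have been measured in a functional assay on HeLa cells for antagonist activity at 5-hydroxytryptamine receptor 6 (Homo sapiens); on this read-out lower numbers stand for stronger inhibition and higher numbers for weaker inhibition. Compound 1 `CN1CCN(c2ccc3[nH]nc(S(=O)(=O)c4ccccc4Cl)c3c2)CC1` gives 101 nM in this assay, which is the higher of the two numbers. Compound 2 `CCn1nc(S(=O)(=O)c2cccc3ccccc23)c2cc(N3CCN(C)CC3)ccc21` gives 1.7 nM, a number far lower than that of compound 1 and beyond the usual scatter, though the two differ in more than one place, so no single change can be held responsible for the gap.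

The unmeasured compound 3 `COc1ccc(S(=O)(=O)c2n[nH]c3ccc(N4CCN(C)CC4)cc23)cc1` differs from compound 1 in one place: 4-methoxyphenyl in place of 2-chlorophenyl on a sulfonyl sulfur. Among the measured compounds shown here, no pair differing only in this way has been measured here, so the direction of the step must be judged without a direct precedent.

The author expects compound 3 to return a somewhat lower number than compound 1, a step in this assay of a 2.5-fold lower number from compound 1 to compound 3 (0.40 log units; beyond the scatter), which may reach just beyond the scatter but could also fall within it. On this basis compound 3 is estimated at 40 nM, with a likely range from 8 nM to 200 nM in this assay.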

Compound 3, half-maximal inhibitory concentration: 544 nM
The estimate for compound 3 lay 14-fold (1.13 log units) below the measured number; the measured number lies above the stated range.
By their numbers in this assay, from the lowest: compound 2; then compound 1; then compound 3.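

Among the compounds shown here, with the core of compound 1 held constant, this is the first comparison in this assay that isolates the aryl group on the sulfonyl sulfur. Replacing 2-chlorophenyl with 4-methoxyphenyl gives a 5.4-fold higher number from compound 1 to compound 3 (0.73 log units; beyond the scatter), so inhibition weakens beyond the usual scatter and the identity of this group clearly matters on this core. The entering group brings one hydrogen-bond acceptor and the leaving group none, but nothing available accounts for the weaker inhibition.

The change swaps the substituent and its printed ring position together, leaving open whether the loss follows the replacement of chlorine by methoxy or the move from the 2-position to the 4-position, a question that 2-methoxyphenyl and 4-chlorophenyl on the same sulfonyl sulfur could separate. Also open, on these data alone, is how unsubstituted phenyl would compare with both groups, and whether the same swap would have a similar effect in a compound carrying the ethyl group found on compound 2.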